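Fluoro at the meta position on a thiazole-fused carbamate series

A few compounds are considered here, and "the series" means these few. Any claim that something is new, unique, unknown or untested is made for them only; others in the source may bear on it.

Compound 1 `Cc1c(C(C)OC(=O)Nc2ccccc2)oc2ncnn12`: 63.1 nM
Compound 2 `Cc1c(C(C)OC(=O)Nc2cccc(Cl)c2)oc2ncnn12`: 39.8 nM
Compound 3 `Cc1c(C(C)OC(=O)Nc2ccccc2)sc2nncn12`: 126 nM

Three carbamates have been measured in a functional assay on CHO cells for antagonist activity at metabotropic glutamate receptor 5 (Homo sapiens), read by calcium flux; on this read-out higher numbers stand for weaker inhibition and lower numbers for stronger inhibition. Compound 3 gives 126 nM, the highest number of the three. Its nearest neighbour is compound 1, which gives 63.1 nM; that gap lies within the scatter, so no order can be drawn between the two. Compound 2 gives 39.8 nM, and here the gap to compound 3 lies beyond the scatter. Among the compounds with values here, no single-point step links compound 3 to either of these, as its core differs from theirs, so only the bare values can be compared.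

Compound 4 `Cc1c(C(C)OC(=O)Nc2cccc(F)c2)sc2nncn12` differs from compound 3 by one change: fluoro in place of hydrogen on an aromatic carbon. Within the data shown here, the one measured step that bears on it is a 1.6-fold lower number from compound 1 to compound 2 (0.20 log units; within the scatter), a change of the same kind at the same place, though with a larger halogen and on the other core. Since that step stayed within the scatter, the step from compound 3 to compound 4 in this assay is expected to be small as well, a 1.3-fold lower number from compound 3 to compound 4 (0.10 log units; within the scatter), with the direction uncertain. Compound 4 is therefore estimated at 100 nM, in a range from 40 nM to 250 nM.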

Compound 4, half-maximal inhibitory concentration: 63.1 nM
Beside the measured number, compound 4's estimate is 1.6-fold (0.20 log units) above it, within the range that was stated.
By their numbers in this assay, from the lowest: compounds 2, 1, 4 and 3 (each within the scatter of the next, the first and the last beyond it).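

In this assay the change from phenyl to 3-fluorophenyl gives a 2.0-fold lower number from compound 3 to compound 4 (0.30 log units; within the scatter) and so stays inside the scatter on the core of compound 3, which shows that a fluoro on this aromatic carbon does not separate the two compounds on this read-out. Until now the only step at this place was a 1.6-fold lower number from compound 1 to compound 2 (0.20 log units; within the scatter), with a chloro on the other core, and the new step adds a second halogen and a second core with the same reading: both steps lie within the scatter, and no compound shown goes against this. Nothing in the data given accounts for the size of either step.

What stays open is whether any group on this aromatic carbon can move the number beyond the scatter, for instance an amine, a carboxylic acid or a methoxy group, since only the two halogens are shown here. Also open, from the compounds shown here alone, is what a chloro would do on the core of compound 3, and what a fluoro would do on the core of compound 1.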